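This account rests on a few compounds, and the source may have more. Where it says the series, first, only, none or still open, it means among the compounds named here.

Compound 3, whose structure is `COc1cc(NC(=O)Nc2cc(Nc3ccc(C)c(F)c3)ncn2)cc(OC)c1`, gives 38% in a functional assay on NCI-H1581 cells (Homo sapiens) for inhibition, read by MTT assay, with a stated time of 48 h, tested at 10 uM (a lower number here means less inhibition, a higher number more inhibition at the concentration tested (going by the name of the read-out)), the lowest of the three numbers measured. Compound 1, `COc1ccc(Br)cc1Nc1cc(NC(=O)Nc2c(Cl)cccc2Cl)ncn1`, gives 53.3%, and compound 2, `COc1ccc(C(F)(F)F)cc1Nc1cc(NC(=O)Nc2c(Cl)cccc2Cl)ncn1`, gives 69.1%; both sit higher than compound 3 by steps beyond the scatter. Compound 4, `COc1cc(NC(=O)Nc2cc(Nc3cc(F)ccc3OC)ncn2)cc(OC)c1`, has not been measured yet. It differs from compound 3 in one place: 5-fluoro-2-methoxyphenyl in place of 3-fluoro-4-methylphenyl on a nitrogen on an aromatic ring.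

For the measured compounds named here, only one measured step is known, and it changes a different part of the molecule: a number 15.8 percentage points higher from compound 1 to compound 2 (beyond the scatter), where trifluoromethyl replaces bromo on an aromatic carbon. That step bears on the present change only loosely, since compound 3 to compound 4 swaps the whole aromatic group on the nitrogen rather than one substituent on it. Compounds 1 and 2 both carry a methoxy on that aromatic group and both gave higher numbers than compound 3, but each also differs from compound 3 elsewhere, so no clean comparison exists. The step is therefore expected to be small, a number 7 percentage points higher from compound 3 to compound 4 (within the scatter), with wide uncertainty. Compound 4 is expected to give about 45%, within a range of 27% to 63%.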

Compound 4, a percentage reported as inhibition, at one concentration (the size of the read-out at that concentration, not a potency): 42.1%
For compound 4 the middle estimate is 2.9 percentage points above the measured one, within the range that was stated.
By their numbers in this assay, from the lowest: compounds 3 and 4 (each within the scatter of the next); then compound 1; then compound 2.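

With the rest of compound 3 held fixed, exchanging the whole group on the nitrogen in this assay gives a number 4.1 percentage points higher from compound 3 to compound 4 (within the scatter), so at this position the read-out does not separate 3-fluoro-4-methylphenyl from 5-fluoro-2-methoxyphenyl. The entering group has one more heavy atom and one hydrogen-bond acceptor where the leaving group has none, and this swap of substituents still produces no step beyond the scatter. Nothing shown gives a reason for this result.

On these data alone, whether an amine or a carboxylic acid on this aromatic group would move the number remains open, as does the effect of a longer chain in place of the methoxy. As far as these compounds go, it is also open whether the two groups would still read alike with the other end of the molecule as in compound 1.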